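A few compounds are considered here, and "the series" means these few. Any claim that something is new, unique, unknown or untested is made for them only; others in the source may bear on it.

Measured compounds:
compound 1, `O=c1cc(Cn2ccnc2)c2ccc(OCc3cccc(Cl)c3)cc2o1`, gives 101 nM in an assay on V79MZh11B2 cells for inhibition of cytochrome P450 11B2, mitochondrial (Homo sapiens), read by HPLC, with a stated time of 25 min; on this read-out lower numbers stand for stronger inhibition and higher numbers for weaker inhibition
compound 2, `O=c1cc(Cn2ccnc2)c2ccc(OCc3cccc(C(F)(F)F)c3)cc2o1`, gives 150 nM in this assay
compound 3, `COc1ccc(COc2ccc3c(Cn4ccnc4)cc(=O)oc3c2)cc1`, gives 124 nM in this assay

In this assay compound 3 sits among three numbers that all lie within the scatter of one another: the step of a 1.2-fold higher number from compound 1 to compound 3 (0.09 log units; within the scatter) is within it, and the gap between compound 3 and compound 2 is likewise within the scatter. Compound 4, `O=c1cc(Cn2ccnc2)c2ccc(OCc3cccc(F)c3)cc2o1`, differs from compound 3 by 3-fluorophenyl in place of 4-methoxyphenyl on a saturated chain carbon bound to an oxygen on an aromatic ring. Within the data shown here, two measured steps bear on this change. The step of a 1.2-fold higher number from compound 1 to compound 3 (0.09 log units; within the scatter) covers the exchange between 4-methoxyphenyl and 3-chlorophenyl at the same place, and the step of a 1.5-fold higher number from compound 1 to compound 2 (0.17 log units; within the scatter) shows that replacing one group by another on that ring also stayed within the scatter. Among the measured compounds shown here, no measured compound carries 3-fluorophenyl, so the exchange of fluoro for chloro itself is untested. Compound 4 is therefore expected to show no step beyond the scatter, a 1.1-fold lower number from compound 3 to compound 4 (0.05 log units; within the scatter). The estimate for compound 4 is 110 nM, with a range from 55 nM to 220 nM.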

Compound 4, half-maximal inhibitory concentration: 200 nM
The estimate for compound 4 lay 1.8-fold (0.26 log units) below the measured number; the range from low to high includes it.
By their numbers in this assay, from the lowest: compounds 1, 3, 2 and 4 (each within the scatter of the next).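

With fluoro now on the ring, the exchange left untested before can be read in this assay: a 2.0-fold higher number from compound 1 to compound 4 (0.30 log units; within the scatter), and fluoro in place of trifluoromethyl gives a 1.3-fold higher number from compound 2 to compound 4 (0.12 log units; within the scatter). The exchange of 4-methoxyphenyl for 3-fluorophenyl gives a 1.6-fold higher number from compound 3 to compound 4 (0.21 log units; within the scatter), so all four groups at this place, on the saturated chain carbon bound to an oxygen on an aromatic ring, remain within the scatter of one another and this series of exchanges has not separated them. Nothing measured beyond these numbers bears on the steps.

Still open is whether 4-fluorophenyl or 3-methoxyphenyl would read like the groups shown, which would separate the group from its place on the ring. On these data alone, it is also open whether an amine or a carboxylic acid on that ring, or a longer chain in place of the benzyl group, would move the number beyond the scatter.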